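The source may hold more compounds than are shown below. What is called first, only, known or untested is meant among the compounds shown, and "the series" means these compounds.

Working notes on the series in a functional assay on the whole organism (strain ICR) for inhibition, with Mus musculus as the target, read by scintillation counting, with a stated time of 16 h, at a dose of 10 mg/kg by the oral route; a higher number here means more inhibition at the dose given (going by the name of the read-out), a lower number less inhibition. Of the compounds shown here, three have a number so far. Compound 1 `Cn1c(-c2ccc(-c3cncnc3)cc2)nnc1C1(c2ccc(Cl)cc2)CCC1` gives -4% in this assay. Compound 2 `CC(=O)Nc1ccc(-c2nnc(C3(c4ccc(Cl)cc4)CCC3)n2C)c(Cl)c1` gives 27% in this assay. Compound 3 `Cn1c(-c2ccc(C(N)=O)cc2C(N)=O)nnc1C1(c2ccc(Cl)cc2)CCC1` gives 0% in this assay. Of these three numbers compound 2 stands highest; compound 3 is the nearest, its number lower by a gap beyond the scatter, and compound 1 lies furthest, its number also lower beyond the scatter. Among the compounds with values here, no two of the measured compounds differ in one place only, so no measured step is at hand to set the size of a single change in this assay.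

Compound 4 `Cn1c(-c2ccc(N)cc2Cl)nnc1C1(c2ccc(Cl)cc2)CCC1` has no number yet. It differs from compound 2 in one place: hydrogen in place of acetyl on a nitrogen on an aromatic ring. Cut one bond further out, the change reads acetamido to amino. Within the data shown here, with no measured step to lean on, the step from compound 2 to compound 4 in this assay is expected to be modest and toward a lower number, though it may also fall within the scatter, because compound 2 gives 27% while compound 1 and compound 3 sit near zero. The step expected from compound 2 to compound 4 is a number 12 percentage points lower from compound 2 to compound 4 (beyond the scatter). Compound 4 is therefore estimated to give about 15%, with a range from -10% to 40%.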

Compound 4, a percentage reported as inhibition, in the whole organism at one dose (the size of the read-out at that dose, not a potency): 38%
The estimate for compound 4 lay 23 percentage points below the measured number; low and high end bracket the measured number.
By their numbers in this assay, from the lowest: compounds 1 and 3 (each within the scatter of the next); then compound 2; then compound 4.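

Within the data shown here, this is the first measured step that turns on one change, and in this assay the change from acetamido to amino, hydrogen in place of acetyl on a nitrogen on an aromatic ring, gives a number 11 percentage points higher from compound 2 to compound 4 (beyond the scatter), a modest step. The acetyl is therefore not required for the read-out at this dose: with the nitrogen left as a plain amino group, the inhibition does not fall, and the step runs upward beyond the scatter. No measurement at hand bears on why the amino compound reads higher.

The compounds shown leave open how other groups on this nitrogen would read, such as a methyl group or a methanesulfonyl group in place of the acetyl, and so whether the step belongs to the loss of acetyl in particular or to any change at this place. From the compounds shown here alone, this remains a single pair at a single dose, so it gives the size of the read-out and not a potency, and whether the same step would hold on a different remainder of the molecule stays unknown.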